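The compounds below may be only part of what the source reports. "The series", "measured", "known", "first", "only" and "open" are said of these compounds alone.

Three compounds with a shared core and a different aryl group on its five-membered ring have been measured. Compound 1 `Cc1oc(-c2c(C)c(C)c(C)c(C)c2C)nc1CN1CCC(C(=O)NCCCN2C[C@H](C)C[C@H](C)C2)CC1` gives 8180 nM in an ADME assay on Huh7.5.1 cells (Homo sapiens) for cytotoxicity, read by ATP content, with a stated time of 48 h; a lower number here means that less compound is tolerated, a higher number that more compound is tolerated. Compound 2 `Cc1oc(-c2c(Cl)cccc2Cl)nc1CN1CCC(C(=O)NCCCN2C[C@H](C)C[C@H](C)C2)CC1` gives 13200 nM in this assay, and compound 3 `Cc1cccc(F)c1-c1nc(CN2CCC(C(=O)NCCCN3C[C@H](C)C[C@H](C)C3)CC2)c(C)o1` gives 13000 nM. The three aryl swaps move the numbers little: a 1.6-fold higher number from compound 1 to compound 2 (0.21 log units; within the scatter), a 1.6-fold higher number from compound 1 to compound 3 (0.20 log units; within the scatter) and a 1.0-fold lower number from compound 2 to compound 3 (0.01 log units; within the scatter). Compound 3 therefore cannot be set apart from either of the other two on this assay.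

Compound 4 `COc1cccc(OC)c1-c1nc(CN2CCC(C(=O)NCCCN3C[C@H](C)C[C@H](C)C3)CC2)c(C)o1` carries a further variation of the same aryl group: 2,6-dimethoxyphenyl in place of 2-fluoro-6-methylphenyl on an aromatic carbon. Every step that bears on it is an exchange of this aryl group, and each of them, from compound 1 to compound 2, from compound 1 to compound 3 and from compound 2 to compound 3, stayed within the scatter. Compound 4 is thus expected to show no step beyond the scatter, a 1.1-fold lower number from compound 3 to compound 4 (0.03 log units; within the scatter). Compound 4 is estimated to give 12000 nM in this assay, with a likely range from 5500 nM to 26000 nM.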

Compound 4, half-maximal cytotoxic concentration: 77100 nM
For compound 4 the middle estimate is 6.4-fold (0.81 log units) below the measured one; measured number outside the range, above it.
By their numbers in this assay, from the lowest: compounds 1, 3 and 2 (each within the scatter of the next); then compound 4.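

On an aromatic carbon of the five-membered ring, next to the ring nitrogen and next to the ring oxygen, the aryl group can clearly move the number in this assay after all, with a 5.9-fold higher number from compound 3 to compound 4 (0.77 log units; beyond the scatter) and a 5.8-fold higher number from compound 2 to compound 4 (0.77 log units; beyond the scatter) and a 9.4-fold higher number from compound 1 to compound 4 (0.97 log units; beyond the scatter) all beyond the scatter, whereas the exchanges among the earlier aryl groups all stayed within it. In the step from compound 3 the group that leaves, 2-fluoro-6-methylphenyl, has 0 hydrogen-bond acceptors and the group that enters, 2,6-dimethoxyphenyl, has 2. Nothing at hand accounts for this rise.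

The compounds shown leave open whether both methoxy groups are needed or a single one would give a similar number. They also leave open whether ethoxy, hydroxy or an amine in their place would do the same.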